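Moving the ring nitrogen of the quinoline in compound 4

The compounds below may be only part of what the source reports. "The series", "measured", "known", "first", "only" and "open" are said of these compounds alone.

Compound 1 `O=C(c1ccc(-c2ccc3ncc(-c4ccc5cnccc5c4)n3c2)cc1)N1CCC(N2CCCCC2)CC1`: 74.7%
Compound 2 `O=C(c1ccc(-c2ccc3ncc(-c4ccc5ncccc5c4)n3c2)cc1)N1CCC(N2CCCCC2)CC1`: 2.41%
Compound 3 `O=C(c1ccc(-c2ccc3ncc(-c4ccc5ncccc5c4)n3c2)cc1)N1CCNCC1`: 49.9%

In an assay on Sf21 cells for inhibition of MAP kinase-interacting serine/threonine-protein kinase 2 (Homo sapiens), read by luminescence and ADP-Glo, with stated times of 10 min and 40 min, tested at 500 nM (a higher number here means more inhibition at the concentration tested (going by the name of the read-out), a lower number less inhibition), compound 3 stands second of the three measured compounds, above compound 2 and below compound 1. Compound 4 `O=C(c1ccc(-c2ccc3ncc(-c4cnc5ccccc5c4)n3c2)cc1)N1CCNCC1` has not yet been measured. It differs from compound 3 in one place: quinolin-3-yl in place of quinolin-6-yl on an aromatic carbon. The atoms are the same, joined differently.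

For the measured compounds named here, one measured step bears on this change, since it also alters the bicyclic aromatic group on the same carbon: a number 72.3 percentage points lower from compound 1 to compound 2 (beyond the scatter). That step shows this assay is highly sensitive to where the ring nitrogen sits in that group. The other step, a number 47.5 percentage points higher from compound 2 to compound 3 (beyond the scatter), concerns the amide end and gives no direct guidance here. Because the step of a number 72.3 percentage points lower from compound 1 to compound 2 (beyond the scatter) was large in one direction and the new pattern, quinolin-3-yl, has not been seen among the measured compounds, the direction for compound 4 cannot be settled; a large shift in either direction is plausible.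

Compound 4 is therefore expected at 40%, with a wide range of 5% to 80%; this estimate corresponds to an expected step of a number 9.9 percentage points lower from compound 3 to compound 4 (within the scatter) in this assay.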

Compound 4, a percentage reported as inhibition, at one concentration (the size of the read-out at that concentration, not a potency): 68.1%
Estimate against measurement, compound 4: 28.1 percentage points below; measured number inside the range.
By their numbers in this assay, from the lowest: compound 2; then compound 3; then compounds 4 and 1 (each within the scatter of the next).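

With the piperazin-1-yl amide held constant, exchanging quinolin-6-yl for quinolin-3-yl on the same aromatic carbon gives a number 18.2 percentage points higher from compound 3 to compound 4 (beyond the scatter) in this assay, so rearranging the same atoms in this group changes inhibition even on the amide that had already recovered activity. Quinolin-6-yl is now the lower member of both isomeric pairs, since the earlier pair on the 4-(piperidin-1-yl)piperidin-1-yl amide gave a number 72.3 percentage points lower from compound 1 to compound 2 (beyond the scatter), although the two pairs carry different amides and their steps are not like for like. No measurement available here accounts for the difference between the two quinoline isomers.

From the compounds shown here alone, it remains open whether quinolin-3-yl would also raise inhibition on the 4-(piperidin-1-yl)piperidin-1-yl amide, where the quinolin-6-yl compound 2 gives 2.41%, or whether its gain depends on the piperazin-1-yl amide. Nor do the compounds shown tell whether any ring nitrogen is needed in this group, which naphthalen-2-yl, with its two rings of carbon only, would address, and all these readings remain percentages at a single concentration rather than potencies.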